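A few compounds are considered here, and "the series" means these few. Any claim that something is new, unique, unknown or untested is made for them only; others in the source may bear on it.

Compound 1 `Cc1ccc(-c2ccnc(Nc3ccc4c(c3)c(/C=C3/C(=O)Nc5ccccc53)cn4C)n2)cc1` gives > 100000 nM in a functional assay on U-87MG ATCC cells (Homo sapiens) for cytotoxicity, read by MTT assay, with a stated time of 48 h (on this read-out lower numbers stand for stronger inhibition and higher numbers for weaker inhibition), a limit of the assay. Compound 2 `Cn1cc(/C=C2/C(=O)Nc3ccccc32)c2cc(Nc3nccc(-c4ccc(O)cc4)n3)ccc21` gives 13200 nM in this assay. Compound 3 `Cn1cc(/C=C2/C(=O)Nc3ccccc32)c2cc(Nc3nccc(-c4ccc(C(F)(F)F)cc4)n3)ccc21` gives 26000 nM in this assay.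

Compound 2 holds the lowest of the two numbers shown; the nearest is compound 3, with a 2.0-fold higher number from compound 2 to compound 3 (0.29 log units; within the scatter), so the two are not separated. Compound 1 sits at the limit of > 100000 nM in this assay, at which 1 of the 3 values shown sits. Compound 4 `Cn1cc(/C=C2/C(=O)Nc3ccccc32)c2cc(Nc3nccc(-c4cccs4)n3)ccc21` is compound 2 with thiophen-2-yl in place of 4-hydroxyphenyl on an aromatic carbon. The steps bearing on it are those at the same place: an at least 7.5-fold lower number from compound 1 to compound 2 (0.87 log units; beyond the scatter) and an at least 3.8-fold lower number from compound 1 to compound 3 (0.58 log units; beyond the scatter), both at least modest, whereas a 2.0-fold higher number from compound 2 to compound 3 (0.29 log units; within the scatter) is within the scatter. Going by the values given here, no measured step introduces thiophen-2-yl. The expectation is therefore a number in the range of compound 2 and compound 3, with a step of a 1.5-fold higher number from compound 2 to compound 4 (0.18 log units; within the scatter). Compound 4 is estimated at 20000 nM, from 7000 nM to 60000 nM.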

Compound 4, half-maximal inhibitory concentration: 7180 nM
For compound 4 the middle estimate is 2.8-fold (0.44 log units) above the measured one; the measured number falls inside the stated range.
By their numbers in this assay, from the lowest: compounds 4, 2 and 3 (each within the scatter of the next, the first and the last beyond it). At a limit, above all of these: compound 1.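

The thiophen-2-yl ring carries no hydrogen-bond donor, yet in this assay it is not separated from 4-hydroxyphenyl: a 1.8-fold lower number from compound 2 to compound 4 (0.26 log units; within the scatter), so a hydroxy donor is not required at this position. Against 4-(trifluoromethyl)phenyl, the same change gives a 3.6-fold lower number from compound 3 to compound 4 (0.56 log units; beyond the scatter), a step beyond the scatter among the aryl groups with measured numbers. Against 4-methylphenyl the step reads an at least 13-fold lower number from compound 1 to compound 4 (1.14 log units; beyond the scatter), and its starting value is a limit: the limit of > 100000 nM in this assay, at which 1 of the 4 values shown sits.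

Furan-2-yl, pyridin-3-yl, morpholine and a simple amine at this position remain open. Also open, on these data alone, is whether the sulfur or the smaller ring sets the number of compound 4.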